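The source may report more compounds than this note shows. Statements on the series, on what has been measured and on what is new or still open speak of the compounds shown alone.

Working notes on a small series of fused bicyclic thiophene amides carrying a diethylamide and a thiophene-carboxamide. Compound 1 `CCN(CC)C(=O)c1c(NC(=O)c2cccs2)sc2c1CC(C)CC2` and compound 2 `CCN(CC)C(=O)c1c(NC(=O)c2cccs2)sc2c1CCC(C)C2` share the same atoms joined differently; the difference between the two cores is not broken down here. Compound 3 `CCN(CC)C(=O)c1c(NC(=O)c2cccs2)sc2c1CC(C)(C)CC2` is compound 1 with a methyl added (methyl in place of hydrogen on a saturated ring carbon). Compound 4 `CCN(CC)C(=O)c1c(NC(=O)c2cccs2)sc2c1CCC(C)(C)C2` is the corresponding product from compound 2, carrying a methyl added (methyl in place of hydrogen on a saturated ring carbon); the two place descriptions read the same word for word, so the change is taken as the same change in both pairs.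

In a functional assay on A549 cells (Homo sapiens) for cytotoxicity, with a stated time of 60 h (on this read-out higher numbers stand for an effect only at larger amounts of compound and lower numbers for an effect already at smaller amounts), compound 1 gives 1000 nM. In this assay compound 3 gives 6000 nM, which is a step of a 6.0-fold higher number from compound 1 to compound 3 (0.78 log units; beyond the scatter). Compound 2, in this assay, gives 6100 nM, standing within the scatter of compound 3 and beyond it from compound 1.

Among the measured compounds shown here, for compound 4 the only guide is the one measured instance of this change. Because a 6.0-fold higher number from compound 1 to compound 3 (0.78 log units; beyond the scatter) lies beyond the scatter, the expectation is that the same added methyl raises the number again on the core of compound 2, though with one example the size is uncertain. The step from compound 2 to compound 4 is estimated as a 4.1-fold higher number from compound 2 to compound 4 (0.61 log units; beyond the scatter). Compound 4 is estimated in this assay at 25000 nM, with a likely range from 7000 nM to 80000 nM.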

Compound 4, half-maximal effective concentration: 24000 nM
Compound 4: middle estimate off by 1.0-fold (0.02 log units), on the high side; the measured number falls inside the stated range.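

On the second core, methyl in place of hydrogen on a saturated ring carbon gives in this assay a 3.9-fold higher number from compound 2 to compound 4 (0.59 log units; beyond the scatter). Set beside the earlier instance, the change goes the same way on both cores, and the two step sizes do not separate: the same change on two cores in this assay, a 6.0-fold higher number (0.78 log units; beyond the scatter) from compound 1 to compound 3 and a 3.9-fold higher number (0.59 log units; beyond the scatter) from compound 2 to compound 4, 1.5-fold (0.18 log units) apart, within the scatter of two such steps. This shows that, within these two cores, the added methyl carries over in direction and in size as far as the scatter can tell, but it rests on two pairs only, in one cytotoxicity read-out on one cell line at one stated time, and it shows neither why the number rises nor whether the same holds on any other core.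

The compounds shown leave open whether the rise belongs to methyl itself or would also come with another group on that saturated ring carbon, such as an ethyl, a longer chain, a hydroxyl or an amine. They also leave open whether the step would hold if the diethylamide or the thiophene-carboxamide gave way to another group, for example a carboxylic acid or a phenyl amide.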